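From bromo to acetamido: estimating compound 4

The source may hold more compounds than are shown below. What is called first, only, known or untested is meant among the compounds shown, and "the series" means these compounds.

In an ADME assay on L02 cells (Homo sapiens) for cytotoxicity, read by MTT assay, with a stated time of 24 h (on this read-out higher numbers stand for weaker inhibition and lower numbers for stronger inhibition), three compounds have been measured so far. Compound 3 (`O=C1/C(=C/c2ccncc2)CN(S(=O)(=O)c2ccc(Br)cc2)C/C1=C\c1ccccc1C(F)(F)F`) gives 12600 nM. Compound 2 (`O=C1/C(=C/c2ccncc2)CN(S(=O)(=O)c2ccc(Cl)cc2)C/C1=C\c1ccccc1C(F)(F)F`) gives 14900 nM, and compound 1 (`CC(=O)Nc1ccc(S(=O)(=O)N2C/C(=C\c3cccnc3)C(=O)/C(=C/c3ccccc3C(F)(F)F)C2)cc1`) gives 15300 nM. All three numbers lie within the scatter of one another, so compound 3 does not stand apart from either neighbour.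

Compound 4 (`CC(=O)Nc1ccc(S(=O)(=O)N2C/C(=C\c3ccncc3)C(=O)/C(=C/c3ccccc3C(F)(F)F)C2)cc1`) is reached from compound 3 by one change, acetamido in place of bromo on an aromatic carbon. Within the data shown here, the only measured step in one place, bromo in place of chloro on an aromatic carbon, is a 1.2-fold lower number from compound 2 to compound 3 (0.07 log units; within the scatter), and it stays within the scatter. That step exchanges one halogen for another, so it is only a loose guide to a much larger group. Among the measured compounds shown here, no measured step isolates acetamido. However, compound 1 already carries this group and gives 15300 nM, although it also differs from compound 4 in another part of the structure. On this evidence, no step beyond the scatter is expected in this assay. The expected step is a 1.1-fold higher number from compound 3 to compound 4 (0.05 log units; within the scatter). Compound 4 is estimated at 14000 nM, with an expected range from 8000 nM to 25000 nM.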

Compound 4, half-maximal inhibitory concentration: 10100 nM
Estimate against measurement, compound 4: 1.4-fold (0.14 log units) above, within the range that was stated.
By their numbers in this assay, from the lowest: compounds 4, 3, 2 and 1 (each within the scatter of the next).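

At the aromatic carbon para to a large group, this assay now compares three groups in compounds that differ only there: acetamido in place of bromo gives (a 1.2-fold lower number from compound 3 to compound 4 (0.10 log units; within the scatter)), and acetamido in place of chloro gives (a 1.5-fold lower number from compound 2 to compound 4 (0.17 log units; within the scatter)). Replacing a single halogen atom with acetamido, which brings a hydrogen-bond donor and a hydrogen-bond acceptor, therefore stays within the scatter at this place, as the exchange of one halogen for another did, so these compounds show no sensitivity of this read-out to the group there. Among these compounds, compounds 1 and 4 also give the first comparison at a second place, and pyridin-4-yl in place of pyridin-3-yl, with acetamido held constant, stays within the scatter too (a 1.5-fold lower number from compound 1 to compound 4 (0.18 log units; within the scatter)).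

No measurement shown here explains why these steps stay so small. On these data alone, it remains open whether an amine or a carboxylic acid at the same aromatic carbon, or a pyridin-2-yl group on the double-bonded chain carbon, would also leave the number within the scatter.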